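Aryl swap in the amide series: tolerability outlook

The compounds below may be only part of what the source reports. "The series", "measured", "known", "first", "only" and "open" are said of these compounds alone.

Compound 2 `Cn1c(-c2ccccc2F)cnc1NC(=O)c1ccc(F)cc1` in a toxicity assay on THP-1 cells (Homo sapiens) for inhibition (a higher number here means that more compound is tolerated, a lower number that less compound is tolerated), returns only a limit, > 100000 nM. Compound 1 `Cn1c(-c2ccc(C#N)cc2)cnc1NC(=O)c1ccc(F)cc1` likewise stops at a limit, > 50000 nM. Compound 3 `COc1ccc(-c2cnc(NC(=O)c3ccccn3)n2C)cc1` also sits at a limit, > 100000 nM. Among the measured compounds shown here, two of the three values thus rest at the limit of > 100000 nM in this assay, at which 2 of the 3 values shown sit, and one at the limit of > 50000 nM in this assay, at which 1 of the 3 values shown sits, and the single measured step, a step that the two limits leave unreadable from compound 1 to compound 2, gives no readable size. Compound 4 `COc1cccc(-c2cnc(NC(=O)c3ccc(F)cc3)n2C)c1` carries 3-methoxyphenyl in place of 2-fluorophenyl on an aromatic carbon. For the measured compounds named here, no measured step bears readably on that change; all three aryl variants so far were tolerated up to the ceiling of this assay, so no shift beyond the scatter is expected and a further limit is likely. For compound 4 the estimate in this assay is 100000 nM, within 50000 nM to 200000 nM. Accordingly the expected step is a number no higher from compound 2 to compound 4 (the limit leaves the size open).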

Compound 4, half-maximal cytotoxic concentration: > 100000 nM
Compound 4 was reported as a limit (the forecaster's own chance of this, stated with the estimate: 85%); the middle value lies on the limit itself.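

In this assay, among the compounds shown here, compound 4 gives > 100000 nM, which is a limit, so no step from compound 1 or compound 2 to compound 4 can be read. The compounds shown leave open where any true cytotoxic concentration lies, and whether these aryl swaps shift it.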